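The source may report more compounds than this note shows. Statements on the series, on what has been measured and on what is new or still open speak of the compounds shown alone.

Two compounds of the series have been run in a functional assay on the whole organism (strain Sprague-Dawley) for inhibition, with Rattus norvegicus as the target; on this read-out lower numbers stand for an effect already at smaller amounts and higher numbers for an effect only at larger amounts of compound. Compound 1, `CCc1ccc2c(=O)c(-c3nn[nH]n3)c[nH]c2c1`, gives in this assay > 10 mg/kg, a limit of the assay and not a number. Compound 2, `COc1ccc2ncc(-c3nn[nH]n3)cc2c1`, gives in this assay > 25 mg/kg, again a limit rather than a number. Compound 2 thus stands at one of the two limits recorded, with no numeric value beside it; the limit of > 10 mg/kg in this assay, at which 1 of the 2 values shown sits, and the limit of > 25 mg/kg in this assay, at which 1 of the 2 values shown sits, are all the evidence there is, and nothing separates the two compounds beyond the scatter.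

Compound 3, `c1nc2ccc(C3CCCCC3)cc2cc1-c1nn[nH]n1`, is not yet measured. It differs from compound 2 as follows: cyclohexyl in place of methoxy on an aromatic carbon. Within the data shown here, no step between measured compounds exists, so the size of this change cannot be read from data. The step expected in this assay is a number no higher from compound 2 to compound 3 (the limit leaves the size open), within the scatter in either direction. Compound 3 is expected to give about 25 mg/kg, between 8 mg/kg and 80 mg/kg, with a fair chance that only a limit is reported.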

Compound 3, minimum effective dose: > 25 mg/kg
Compound 3 ended at the assay's limit; the forecaster's own chance of this, stated with the estimate: 65%; the middle value lies on the limit itself.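

Among these compounds, compound 2 and compound 3 both stand at a limit in this assay and no step between them can be read. Open remains whether cyclohexyl in place of methoxy on an aromatic carbon changes the minimum effective dose at all, and at what dose any compound shown takes effect.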